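Chloro on the anilino ring in a cytotoxicity series

This account rests on a few compounds, and the source may have more. Where it says the series, first, only, none or still open, it means among the compounds named here.

Compound 1 `COc1cccc(/C=C/C(=O)c2sc(Nc3ccc(Cl)cc3)nc2C)c1`, compound 2 `COc1cccc(/C=C/C(=O)c2sc(Nc3ccccc3)nc2C)c1` and compound 3 `Cc1nc(Nc2cccc(Cl)c2)sc1C(=O)/C=C/c1ccccc1` have been tested in a functional assay on Bel-7402 cells (Homo sapiens) for cytotoxicity, read by MTT assay; on this read-out higher numbers stand for weaker inhibition and lower numbers for stronger inhibition. In this assay compound 1 gives only a limit, > 25000 nM. Compound 2 likewise gives only a limit, > 25000 nM. Compound 3 also gives only a limit, > 25000 nM. The change from compound 2 to compound 1, (chloro in place of hydrogen on an aromatic carbon), therefore yields a step that the two limits leave unreadable from compound 2 to compound 1, with every value at the limit of > 25000 nM in this assay, at which 3 of the 3 values shown sit. The difference between the core of compound 3 and that of compound 2 is not broken down here. Compound 4 `Cc1nc(Nc2ccc(Cl)c(Cl)c2)sc1C(=O)/C=C/c1ccccc1`, not yet measured, differs from compound 3 by chloro in place of hydrogen on an aromatic carbon; this is the same kind of change as from compound 2 to compound 1, but here the entering chloro sits ortho to a chloro group as well as para to a large group. Because compound 3 sits at the limit of > 25000 nM in this assay, at which 3 of the 3 values shown sit, the step that the limit leaves unreadable from compound 3 to compound 4 is expected to remain unreadable as well. Compound 4 is estimated at 30000 nM.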

Compound 4, half-maximal inhibitory concentration: 21500 nM
For compound 4 the middle estimate is 1.4-fold (0.14 log units) above the measured one; low and high end bracket the measured number.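

In this assay, the change from 3-chlorophenyl to 3,4-dichlorophenyl gives an at least 1.1-fold lower number from compound 3 to compound 4 (0.06 log units; that floor lies within the scatter), so only a floor is known and it does not establish a real shift. Compound 4 gives 21500 nM, and this single number does not fix the size of the step. Whether the change acts alike on the two cores is not shown, because the step on the core of compound 2 cannot be read either, and most of the series sits at an assay limit: the limit of > 25000 nM in this assay, at which 3 of the 4 values shown sit.

Going by these compounds, it remains open whether any compound reaches a value well clear of that limit in this assay. Also open, on these data alone, is what a group other than chloro, such as an amine or a carboxylic acid, would do on the anilino ring.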